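Compound 3 to compound 4: leaving the carboxyazetidine

The source may report more compounds than this note shows. Statements on the series, on what has been measured and on what is new or still open speak of the compounds shown alone.

In a functional assay on MC-38 cells (Mus musculus) for antiproliferative activity, read by CCK-8 assay, with a stated time of 48 h (a higher number here means a weaker inhibitor, a lower number a stronger inhibitor), compound 3 (`COc1ccc(/C=C\c2cc(OC)c(OC)c(OC)c2)cc1OCc1ccc(CN2CC(C(=O)O)C2)cc1`) stands at > 10000 nM as a limit of the assay and not a number. Compound 1 (`COc1ccc(/C=C\c2cc(OC)c(OC)c(OC)c2)cc1OCc1ccc(C=O)cc1`) gives 900 nM and compound 2 (`COc1ccc(/C=C\c2cc(OC)c(OC)c(OC)c2)cc1OCc1ccc(CNCCO)cc1`) gives 1200 nM in this assay. Compound 4 (`COc1ccc(/C=C\c2cc(OC)c(OC)c(OC)c2)cc1OCc1ccc(CNCCNC(C)=O)cc1`) brings (2-acetamidoethyl)amino in place of 3-carboxyazetidin-1-yl on a saturated chain carbon bound to an aromatic carbon with (2-acetamidoethyl)amino in place of 3-carboxyazetidin-1-yl. Two measured steps introduce that azetidine: an at least 11-fold higher number from compound 1 to compound 3 (1.04 log units; beyond the scatter) is large and an at least 8.3-fold higher number from compound 2 to compound 3 (0.92 log units; beyond the scatter) is at least modest. By contrast, a 1.3-fold higher number from compound 1 to compound 2 (0.12 log units; within the scatter) stays within the scatter. Removing the azetidine is therefore expected to lower the number in this assay, toward the values of compound 1 and compound 2. The expected step is an at least 7.1-fold lower number from compound 3 to compound 4 (0.85 log units; beyond the scatter) in the direction of stronger inhibition. The estimate for compound 4 is 1400 nM within a range of 550 nM to 3800 nM.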

Compound 4, half-maximal inhibitory concentration: 1800 nM
Beside the measured number, compound 4's estimate is 1.3-fold (0.11 log units) below it; the measured number falls inside the stated range.
By their numbers in this assay, from the lowest: compounds 1, 2 and 4 (each within the scatter of the next). At a limit, above all of these: compound 3.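

In this assay, (2-acetamidoethyl)amino in place of 3-carboxyazetidin-1-yl gives an at least 5.5-fold lower number from compound 3 to compound 4 (0.74 log units; beyond the scatter). Compound 3 stands at a limit of the assay and not a number: the limit of > 10000 nM in this assay, at which 1 of the 4 values shown sits.

Acetamido in place of hydroxy gives a 1.5-fold higher number from compound 2 to compound 4 (0.18 log units; within the scatter), and the full replacement of formyl gives a 2.0-fold higher number from compound 1 to compound 4 (0.30 log units; within the scatter), so formyl and both open-chain amines lie within the scatter, with only compound 3 going against this.

Compound 3 carries both a carboxylic acid and a four-membered ring, and the compounds shown do not separate the two. An unsubstituted azetidine or an open-chain amine ending in a carboxylic acid would separate them.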